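Chain-end changes on the spirocyclic amide series

This account rests on a few compounds, and the source may have more. Where it says the series, first, only, none or still open, it means among the compounds named here.

Compound 1 `CC(C)(C)OC(=O)NCCCCCNC(=O)CN1CN(c2ccccc2)C2(CCN(C(=O)c3ccc(C(C)(C)C)cc3)CC2)C1=O` gives 13700 nM in an assay on HEK293 cells for displacement of a labelled ligand from NPC1-like intracellular cholesterol transporter 1 (Homo sapiens) (on this read-out higher numbers stand for weaker inhibition and lower numbers for stronger inhibition), the highest of the three numbers measured. Compound 2 `COC(=O)CCNC(=O)CN1CN(c2ccccc2)C2(CCN(C(=O)c3ccc(C4CCCCC4)cc3)CC2)C1=O` gives 12900 nM, within the scatter of compound 1. Compound 3 `CS(=O)(=O)NCCCNC(=O)CN1CN(c2ccccc2)C2(CCN(C(=O)c3ccc(C4CCCCC4)cc3)CC2)C1=O` gives 3800 nM, the only one beyond the scatter from compound 1.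

Compound 4 `CC(C)(C)c1ccc(C(=O)N2CCC3(CC2)C(=O)N(CC(=O)NCCCCO)CN3c2ccccc2)cc1` differs from compound 1 by hydroxy in place of ((tert-butoxycarbonyl)amino)methyl on a saturated chain carbon, four bonds along the chain from an amide-type nitrogen.

Among the compounds with values here, the one measured step that bears on it is a 3.4-fold lower number from compound 2 to compound 3 (0.53 log units; beyond the scatter), also a replacement on a saturated chain carbon reached from an amide-type nitrogen, though two bonds rather than four along the chain, and with a different group entering. That step was modest, so for compound 4 a step of similar size or smaller is expected, in either direction, with a slightly lower number as the more likely outcome.

Compound 4 is therefore estimated at 10000 nM, with a range of 3500 nM to 30000 nM, which means an expected step of a 1.4-fold lower number from compound 1 to compound 4 (0.14 log units; within the scatter).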

Compound 4, half-maximal inhibitory concentration: 19200 nM
Estimate against measurement, compound 4: 1.9-fold (0.28 log units) below; the range from low to high includes it.
By their numbers in this assay, from the lowest: compound 3; then compounds 2, 1 and 4 (each within the scatter of the next).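

Within the data shown here, replacing 4-((tert-butoxycarbonyl)amino)butyl with 3-hydroxypropyl gives a 1.4-fold higher number from compound 1 to compound 4 (0.15 log units; within the scatter), the first change at this chain end on the core of compound 1. A group of 9 heavy atoms can therefore give way to a single oxygen with the two numbers staying within the scatter of each other. At this position, the size of the end group and the carbamate carbonyl are thus not shown to matter in this assay.

As far as these compounds go, it remains open whether an amine or a carboxylic acid in place of the hydroxy would shift the number beyond the scatter. From the compounds shown here alone, the effect of a longer chain carrying the hydroxy is also open.

No measurement here bears on the reason for this result.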